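The source may report more compounds than this note shows. Statements on the series, on what has been measured and on what is new or still open speak of the compounds shown alone.

Compound 1 `CSc1nncc2c(C)nc(C(C)C)n12` is the starting point. In a functional assay for inhibition, with Homo sapiens as the target (on this read-out lower numbers stand for stronger inhibition and higher numbers for weaker inhibition), compound 1 gives > 48000 nM, which is a limit of the assay rather than a number. Compound 2 `CCc1nc(C)c2cnnc(SC)n12` gives > 48000 nM in this assay, again only a limit. Compound 3 `CCCc1nc(C)c2cnnc(SC)n12` gives > 48000 nM in this assay, also a limit. The steps a step that the two limits leave unreadable from compound 1 to compound 2, a step that the two limits leave unreadable from compound 1 to compound 3 and a step that the two limits leave unreadable from compound 2 to compound 3 cannot be read, because every value sits at the limit of > 48000 nM in this assay, at which 3 of the 3 values shown sit. Compound 4 `CSc1nnc(-c2ccccc2)c2c(C)nc(C(C)C)n12` differs from compound 1 by phenyl in place of hydrogen on an aromatic carbon. Among the compounds with values here, none of the measured steps touches this position, so no measured step guides the expectation, and the limit itself suggests a weak response for this shared core. Compound 4 is therefore expected to give about 40000 nM in this assay, within a range from 8000 nM to 200000 nM. That expectation means a step of an at least 1.2-fold lower number from compound 1 to compound 4 (0.07 log units; that floor lies within the scatter), which is estimated rather than measured.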

Compound 4, half-maximal inhibitory concentration: > 48000 nM
Compound 4: only a limit was reported (the forecaster's own chance of this, stated with the estimate: 65%); middle value at least 1.2-fold (0.07 log units) away from the limit.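

The step between compound 1 and compound 4 cannot be read, because both give a limit rather than a number: the limit of > 48000 nM in this assay, at which 4 of the 4 values shown sit. The compounds shown leave open how strongly any of them inhibits, and whether phenyl in place of hydrogen changes that at all.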